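The compounds below may be only part of what the source reports. "The series", "measured", "known", "first", "only" and "open" are said of these compounds alone.

Measured compounds:
- compound 1, `COc1cc(-c2cc(/C=C/C(=O)c3ccc(N)cc3)[nH]n2)cc(OC)c1OC`: 60%
- compound 2, `COc1ccc(C(=O)/C=C/c2cc(-c3cc(OC)c(OC)c(OC)c3)n[nH]2)cc1OC`: 65%

In a functional assay on HCT-15 cells (Homo sapiens) for cytotoxicity, read by sulforhodamine B assay, with a stated time of 48 h, tested at 1 uM (on this read-out lower numbers stand for a stronger effect and higher numbers for a weaker effect at the one concentration tested), compound 1 gives 60% and compound 2 gives 65%. Among the compounds with values here, compound 2 thus stands alongside the only other number; the step of a number 5 percentage points higher from compound 1 to compound 2 (within the scatter) separates them, so the two compounds cannot be told apart on this read-out.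

Compound 3, `COc1ccc(C(=O)/C=C/c2cc(-c3cc(OC)c(OC)c(OC)c3)n[nH]2)cc1`, is the next member and has not yet been measured. It differs from compound 2 by hydrogen in place of methoxy on an aromatic carbon. Within the data shown here, no measured step removes a methoxy group from the shared core: the single step in hand, a number 5 percentage points higher from compound 1 to compound 2 (within the scatter), exchanges the whole aryl group on the carbonyl carbon and stays within the scatter. That step therefore bears on the present change only loosely, as evidence that an alteration of this aryl group left the read-out essentially unmoved.

On this footing compound 3 is expected to give a number close to that of compound 2, with a step of no change at the digits printed from compound 2 to compound 3 (within the scatter), not beyond the scatter in either direction. The estimate for compound 3 in this assay is 65%, with a range from 50% to 80%.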

Compound 3, a percentage reported as activity, at one concentration (the size of the read-out at that concentration, not a potency): 72%
The estimate for compound 3 lay 7 percentage points below the measured number; measured number inside the range.
By their numbers in this assay, from the lowest: compounds 1, 2 and 3 (each within the scatter of the next, the first and the last beyond it).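

In this assay, hydrogen in place of methoxy, which turns 3,4-dimethoxyphenyl into 4-methoxyphenyl, gives a number 7 percentage points higher from compound 2 to compound 3 (within the scatter), so the loss of this methoxy group, ortho to the remaining methoxy group, produces no change that can be read on this measure. Methoxy in place of amino on an aromatic carbon gives a number 12 percentage points higher from compound 1 to compound 3 (beyond the scatter), the first step in the series beyond the scatter: it is modest, and on this read-out it marks a weaker effect for compound 3 than for compound 1. No measurement in hand accounts for either step.

Going by these compounds, it remains open how a hydroxyl group, a dimethylamino group or a carboxylic acid would read on this aryl group, and so whether the separation between compound 1 and compound 3 is particular to the amino group. Since the read-out reports the size of the effect at one concentration, the weaker effect of compound 3 than of compound 1 holds at that concentration only.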